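Inverting One Stereocentre on the Diol Chain

The compounds below may be only part of what the source reports. "The series", "measured", "known", "first", "only" and "open" are said of these compounds alone.

Compound 3 `CC/C=C\C/C=C\C[C@@H](O)[C@H](O)/C=C/[C@@H]1C/C=C\CCCC(=O)O1` gives 4.2 ug/mL in a functional assay on SK-OV-3 cells (Homo sapiens) for cytotoxicity (a lower number here means that less compound is needed, a higher number that more compound is needed for the effect), the lowest of the three numbers here. Compound 1 `CCCCC/C=C\C[C@@H]1O[C@@H]1/C=C/[C@@H]1C/C=C\CCCC(=O)O1` gives 4.6 ug/mL in this assay, within the scatter of compound 3, while compound 2 `CCCCC/C=C\C[C@@H](O)[C@H](O)/C=C/[C@@H]1C/C=C\CCCC(=O)O1` gives 12.3 ug/mL. Going by the values given here, the single measured step, a 2.9-fold lower number from compound 2 to compound 3 (0.47 log units; beyond the scatter), concerns a change of atoms on the chain. Compound 4 `CC/C=C\C/C=C\C[C@H](O)[C@H](O)/C=C/[C@@H]1C/C=C\CCCC(=O)O1` differs from compound 3 in configuration alone: the two compounds have the same atoms and bonds and differ only in configuration as drawn: 1 of 7 stereo elements differ; a stereocentre at a saturated chain carbon is drawn R in compound 3 and S in compound 4. Among the compounds with values here, no measured pair in this set addresses such an inversion, so the chain step offers no guide to it. With nothing to indicate a direction, the step is expected to be a 1.2-fold higher number from compound 3 to compound 4 (0.08 log units; within the scatter). Compound 4 is therefore estimated at 5 ug/mL, with a range from 2.3 ug/mL to 11 ug/mL.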

Compound 4, concentration for half-maximal effect: 6.5 ug/mL
Compound 4: the middle estimate sits 1.3-fold (0.11 log units) below what was measured, within the range that was stated.
By their numbers in this assay, from the lowest: compounds 3, 1, 4 and 2 (each within the scatter of the next, the first and the last beyond it).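

At this saturated chain carbon, the change from R to S gives a 1.5-fold higher number from compound 3 to compound 4 (0.19 log units; within the scatter) in this assay, so this single inversion has no effect that can be told from the usual scatter, unlike the chain change from compound 2 to compound 3. The comparison isolates this one stereocentre: the fact that compounds 3 and 4 differ only in the configuration as drawn

The compounds shown leave open whether the other stereocentre of the diol tolerates inversion as well, and whether the same inversion would read alike on the chain of compound 2. They also leave open how an amine or a methyl ether in place of the hydroxyl on this carbon would read.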